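A few compounds are considered here, and "the series" means these few. Any claim that something is new, unique, unknown or untested is made for them only; others in the source may bear on it.

Compounds measured in a functional assay on the whole organism (strain Lewis) with Rattus norvegicus as the target, with a stated time of 24 h, at a dose of 2 mg/kg by the oral route; on this read-out lower numbers stand for less inhibition and higher numbers for more inhibition at the one dose given (going by the name of the read-out):
- compound 1 `COc1ccccc1OC[C@@H]1CCc2cc([C@H]3CC[C@](N)(CO)C3)ccc2C1`: 85%
- compound 2 `COc1ccc(OC[C@@H]2CCc3cc([C@H]4CC[C@](N)(CO)C4)ccc3C2)c(F)c1F`: 48%
- compound 3 `Cc1ccc(OC[C@@H]2CCc3cc([C@H]4CC[C@](N)(CO)C4)ccc3C2)cc1`: 20%

Compound 3 stands lowest of the three in this assay; the nearest number is that of compound 2 (a number 28 percentage points lower from compound 2 to compound 3 (beyond the scatter)), and the furthest that of compound 1 (a number 65 percentage points lower from compound 1 to compound 3 (beyond the scatter)). The unmeasured compound 4 `COc1cccc(OC[C@@H]2CCc3cc([C@H]4CC[C@](N)(CO)C4)ccc3C2)c1` is reached from compound 3 by a single change: 3-methoxyphenyl in place of 4-methylphenyl on an oxygen on a saturated carbon. Cut one bond further out, this reads 4-methylphenoxy to 3-methoxyphenoxy. Within the data shown here, no measured step swaps exactly these two groups, but two steps bear on it. Both measured compounds carrying a methoxy group on this ring, compound 1 and compound 2, give higher numbers than compound 3 with its 4-methylphenyl, by a number 65 percentage points lower from compound 1 to compound 3 (beyond the scatter) and a number 28 percentage points lower from compound 2 to compound 3 (beyond the scatter). On that basis compound 4 is expected to rise above compound 3 in this assay, by about a number 25 percentage points higher from compound 3 to compound 4 (beyond the scatter), though the spread between compound 1 and compound 2 (a number 37 percentage points lower from compound 1 to compound 2 (beyond the scatter)) shows that where the methoxy group sits matters greatly and leaves the size uncertain. Compound 4 is therefore estimated at 45%, within a range of 15% to 75%.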

Compound 4, a percentage reported as inhibition, in the whole organism at one dose (the size of the read-out at that dose, not a potency): 86%
For compound 4 the middle estimate is 41 percentage points below the measured one, outside the stated range (above it).
By their numbers in this assay, from the lowest: compound 3; then compound 2; then compounds 1 and 4 (each within the scatter of the next).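

In this assay, 3-methoxyphenyl on the oxygen reads far apart from both 4-methylphenyl (a number 66 percentage points higher from compound 3 to compound 4 (beyond the scatter)) and 2,3-difluoro-4-methoxyphenyl (a number 38 percentage points higher from compound 2 to compound 4 (beyond the scatter)). Against 2-methoxyphenyl, the same group shows no readable difference (a number 1 percentage points higher from compound 1 to compound 4 (within the scatter)), so the two singly substituted methoxyphenyl groups are not told apart at this position, while the other two groups both fall well short of 3-methoxyphenyl. Nothing shown here accounts for these differences.

The compounds shown leave open how a plain 4-methoxyphenyl would read, and so whether the lower number of compound 2 goes with the place of its methoxy group or with its two fluorines. Also open, from the compounds shown here alone, is how this position would respond to an ethoxy group, an amine or a carboxylic acid on the ring.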